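This account rests on a few compounds, and the source may have more. Where it says the series, first, only, none or still open, it means among the compounds named here.

Working notes on the series, values in (a functional assay on T29Kt1 cells (Homo sapiens) for cytotoxicity, read by sulforhodamine B assay, with a stated time of 3 days; a lower number here means a stronger inhibitor, a higher number a weaker inhibitor)

- compound 1 `O=Cc1cn(Cc2ccc(Cl)cc2)c2ccc(F)cc12` gives 9090 nM
- compound 2 `OCc1cn(Cc2ccc(Cl)cc2)c2ccccc12` gives 79 nM
- compound 3 `COc1ccc(Cn2cc(CO)c3ccccc32)cc1` gives 63 nM

Compound 2 lies within the scatter of compound 3 in this assay, and compound 1 has a much higher number than both. Within the data shown here, the one measured step (a 1.3-fold lower number from compound 2 to compound 3 (0.10 log units; within the scatter)) is methoxy in place of chloro on an aromatic carbon and stays within the scatter.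

The next compound is compound 4 (`OCc1cn(Cc2ccc(Cl)cc2)c2ccc(F)cc12`). Relative to compound 2, it carries fluoro in place of hydrogen on an aromatic carbon (fluoro in place of hydrogen on an aromatic carbon of a six-membered aromatic ring of carbon only, part of a fused or bridged system of two rings).

Among the measured compounds shown here, no measured step isolates this change, and the step above lies at a different place, so it bears on it only loosely. Compound 1 has the same fluoro but a formyl group instead of hydroxymethyl. No partner without fluoro has been measured, so the value of compound 1 (9090 nM) says nothing about fluoro alone.

No step beyond the scatter is therefore expected in this assay, in either direction. The expected value for compound 4 is 70 nM (estimated range 25 nM to 220 nM). The estimate amounts to an expected 1.1-fold lower number from compound 2 to compound 4 (0.05 log units; within the scatter) (a small change at most).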

Compound 4, half-maximal inhibitory concentration: 80 nM
For compound 4 the middle estimate is 1.1-fold (0.06 log units) below the measured one, and the stated range covers the measured number.
By their numbers in this assay, from the lowest: compounds 3, 2 and 4 (each within the scatter of the next); then compound 1.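

In this assay, among these compounds, the step of a 1.0-fold higher number from compound 2 to compound 4 (0.01 log units; within the scatter) gives the first direct reading of fluoro in place of hydrogen on this aromatic carbon, meta to a fused ring and para to a fused ring, and with hydroxymethyl in place the change leaves the number within the scatter. Among the compounds shown here, with fluoro common to both compounds, the step of a 110-fold lower number from compound 1 to compound 4 (2.06 log units; beyond the scatter) isolates the other site and shows a large difference between formyl and hydroxymethyl on an aromatic carbon, a reading that the earlier compounds, which offered no pair differing only there, could not give. No measured property accompanies these compounds that could account for either step.

Open at the fluoro site is whether a larger group such as chloro, methoxy or nitrile would also stay within the scatter, and whether fluoro would behave the same way alongside the methoxy of compound 3. Open at the other site is how an amine, a carboxylic acid or a longer chain bearing a hydroxyl would compare with hydroxymethyl and formyl.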